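This account rests on a few compounds, and the source may have more. Where it says the series, first, only, none or still open, it means among the compounds named here.

Measured so far in a functional assay on PC-3 cells (Homo sapiens) for inhibition, read by MTT assay, with a stated time of 24 h; a higher number here means a weaker inhibitor, a lower number a stronger inhibitor:

compound 1, `Fc1ccc(-c2cc(/C=N/c3ccccc3)on2)cc1`, 36500 nM
compound 2, `Cc1ccc(-c2cc(/C=N/c3ccccc3)on2)cc1`, 31600 nM
compound 3, `CCc1cc2ccccc2nc1-c1cc(-c2ccc(F)cc2)no1`, for which only a limit is recorded

Compound 1 and compound 2 share a core and differ by methyl in place of fluoro on an aromatic carbon. The step is a 1.2-fold lower number from compound 1 to compound 2 (0.06 log units; within the scatter), so the two values do not separate in this assay.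

Compound 3 belongs to a different core. In this assay compound 3 gives > 100000 nM, which is a limit of the assay and not a number, as noted in the limit of > 100000 nM in this assay, at which 1 of the 3 values shown sits. The difference between the core of compound 1 and the core of compound 3 is not broken down here.

Compound 4, `CCc1cc2ccccc2nc1-c1cc(-c2ccc(C)cc2)no1`, is not yet measured. It differs from compound 3 by methyl in place of fluoro on an aromatic carbon, the same change as that from compound 1 to compound 2, and the place is the same in both cases.

On the core of compound 1 this change gave a 1.2-fold lower number from compound 1 to compound 2 (0.06 log units; within the scatter). Compound 4 is therefore expected to show a step that the limit leaves unreadable from compound 3 to compound 4 from compound 3 in this assay. Compound 4 is estimated at around 120000 nM in this assay, and since compound 3 itself sits at a limit, compound 4 is expected most likely to be reported as a limit as well.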

Compound 4, half-maximal inhibitory concentration: > 100000 nM
Compound 4: only a limit was reported; the forecaster's own chance of this, stated with the estimate: 70%; the middle value lies beyond the limit too.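

In this assay compound 4 gives > 100000 nM, which is a limit of the assay and not a number. Among these compounds, compound 3 also stands at a limit, so no step between compound 3 and compound 4 can be read: the limit of > 100000 nM in this assay, at which 2 of the 4 values shown sit. Still open, going by these compounds, is how far compound 3 and compound 4 lie beyond the limit, and whether 4-fluorophenyl to 4-methylphenyl shifts the value on this core.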